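Thiophen-2-yl for 4-fluorophenyl: a cytotoxicity forecast

A few compounds are considered here, and "the series" means these few. Any claim that something is new, unique, unknown or untested is made for them only; others in the source may bear on it.

Compound 1 `OC[C@H]1O[C@@H](n2cc(F)c3c(-c4ccccc4)ncnc32)[C@H](O)[C@@H]1O`: > 50000 nM (a limit)
Compound 2 `OC[C@H]1O[C@@H](n2cc(F)c3c(-c4ccoc4)ncnc32)[C@H](O)[C@@H]1O`: 350 nM
Compound 3 `OC[C@H]1O[C@@H](n2cc(Cl)c3c(-c4ccc(F)cc4)ncnc32)[C@H](O)[C@@H]1O`: 49500 nM
Compound 4 `OC[C@H]1O[C@@H](n2cc(Cl)c3c(-c4cccs4)ncnc32)[C@H](O)[C@@H]1O`: not yet measured

All values come from an ADME assay on BJ cells (Homo sapiens) for cytotoxicity, read by MTT assay, with a stated time of 72 h; a higher number here means that more compound is tolerated, a lower number that less compound is tolerated. Compound 1 reads > 50000 nM, which is a limit of the assay and not a number. Compound 3, at 49500 nM, holds the higher of the two actual numbers, and compound 2 gives 350 nM. Compound 3 is thus tolerated up to a far higher concentration than compound 2.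

Moving on to compound 4 puts thiophen-2-yl in place of 4-fluorophenyl (thiophen-2-yl in place of 4-fluorophenyl on an aromatic carbon). The swap happens on an aromatic carbon of a six-membered aromatic ring with 2 nitrogen.

For the measured compounds named here, one measured step bears on this: an at least 140-fold lower number from compound 1 to compound 2 (2.15 log units; beyond the scatter), a large change, in which furan-3-yl replaced phenyl. It is a loose guide only. Furan-3-yl is not thiophen-2-yl, the core of compounds 1 and 2 differs from that of compounds 3 and 4, and that step starts from a limit.

Resting on that single step in this assay, a large move towards a lower number is expected. The expected size is a 50-fold lower number from compound 3 to compound 4 (1.69 log units; beyond the scatter), with wide uncertainty. For compound 4 the estimated value is 1000 nM, with an expected range from 100 nM to 20000 nM.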

Compound 4, half-maximal cytotoxic concentration: 4970 nM
The estimate for compound 4 lay 5.0-fold (0.70 log units) below the measured number; the measured number falls inside the stated range.
By their numbers in this assay, from the lowest: compound 2; then compound 4; then compound 3. At a limit, above all of these: compound 1.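

In this assay, the place on the aromatic carbon next to the ring nitrogen now has a step with a real number at both ends: a 10-fold lower number from compound 3 to compound 4 (1.00 log units; beyond the scatter). Together with the earlier step, an at least 140-fold lower number from compound 1 to compound 2 (2.15 log units; beyond the scatter), this gives two swaps of a six-membered carbon ring for a five-membered aromatic ring with one hetero atom, and both lead to a lower number, although on different cores and with different hetero atoms. Only one of these two steps can be sized exactly, as compound 1 carries a limit and not a number: the limit of > 50000 nM in this assay, at which 1 of the 4 values shown sits.

The compounds shown cannot separate the part played by ring size from that of the hetero atom, and they do not tell how thiophen-2-yl and furan-3-yl would compare on one shared core, nor why the number falls in either step. On these data alone, it also remains open how this place would respond to a group without an aromatic ring, such as an amine or a longer carbon chain, or to a six-membered ring carrying a carboxylic acid.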